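Propyl in Place of Methoxy: A Second Test

The source may hold more compounds than are shown below. What is called first, only, known or untested is meant among the compounds shown, and "the series" means these compounds.

Compound 1 `COCOc1ccccc1C[C@H]1C(=O)OC[C@@H]1Cc1ccccc1` and compound 2 `CCCCOc1ccccc1C[C@H]1C(=O)OC[C@@H]1Cc1ccccc1` share a core and differ by propyl in place of methoxy on a saturated chain carbon bound to an oxygen on an aromatic ring. In a functional assay on HL-60 cells (Homo sapiens) for cytotoxicity, read by WST assay, with a stated time of 48 h (on this read-out higher numbers stand for an effect only at larger amounts of compound and lower numbers for an effect already at smaller amounts), compound 1 gives 76000 nM and compound 2 gives 20000 nM, so this change made a 3.8-fold lower number from compound 1 to compound 2 (0.58 log units; beyond the scatter). Compound 3 `COCOc1ccc(C[C@H]2C(=O)OC[C@@H]2Cc2ccccc2)cc1` has the same atoms as compound 1 joined differently; the difference between the two cores is not broken down here. In this assay, compound 3 gives 71000 nM, a number within the scatter of that of compound 1. Compound 4 `CCCCOc1ccc(C[C@H]2C(=O)OC[C@@H]2Cc2ccccc2)cc1` differs from compound 3 by propyl in place of methoxy on a saturated chain carbon bound to an oxygen on an aromatic ring, the same change as between compound 1 and compound 2, at the same place. That single earlier example showed a 3.8-fold lower number from compound 1 to compound 2 (0.58 log units; beyond the scatter). On that basis alone, an expected step of a 3.6-fold lower number from compound 3 to compound 4 (0.55 log units; beyond the scatter) follows. Compound 4 is therefore estimated at 20000 nM, with a likely range from 9000 nM to 45000 nM.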

Compound 4, half-maximal effective concentration: 23000 nM
Compound 4: middle estimate off by 1.2-fold (0.06 log units), on the low side, and the stated range covers the measured number.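

In this assay the change gives a 3.1-fold lower number from compound 3 to compound 4 (0.49 log units; beyond the scatter) on the second core, so the drop seen on the first core appears here too. This shows that propyl in place of methoxy carried over between these two cores, but two pairs in one assay say nothing about other cores or about why the number falls. The two steps agree in size: the same change on two cores in this assay, a 3.8-fold lower number (0.58 log units; beyond the scatter) from compound 1 to compound 2 and a 3.1-fold lower number (0.49 log units; beyond the scatter) from compound 3 to compound 4, 1.2-fold (0.09 log units) apart, within the scatter of two such steps

The compounds shown leave open how a longer chain, an amine or a carboxylic acid in the same place would read. They also leave open whether the same change would carry over on a core that differs more from these two.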